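Swapping 3-(dimethylamino)propyl for butylcarbonyl on the shared core

The source may report more compounds than this note shows. Statements on the series, on what has been measured and on what is new or still open speak of the compounds shown alone.

Of the compounds shown here, three sharing one core have been tested in a functional assay on HepG2 cells (Homo sapiens) for cytotoxicity, read by MTT assay (a higher number here means a weaker inhibitor, a lower number a stronger inhibitor), so far. Compound 1 (`COc1ccc(/C=C/C(=O)c2ccc(OC)c3c2OC(C)(C)C=C3)cc1OCC=C(C)C`) gives > 10000 nM as a limit of the assay and not a number. Compound 2 (`C=CCOc1cc(/C=C/C(=O)c2ccc(OC)c3c2OC(C)(C)C=C3)ccc1OC`) gives > 10000 nM as a limit as well. For the measured compounds named here, compound 3 (`COc1ccc(/C=C/C(=O)c2ccc(OC)c3c2OC(C)(C)C=C3)cc1OCCCN(C)C`) gives 5550 nM as the only actual number among the three.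

Compound 4 (`CCCCC(=O)Oc1cc(/C=C/C(=O)c2ccc(OC)c3c2OC(C)(C)C=C3)ccc1OC`) has not yet been measured. It carries butylcarbonyl in place of 3-(dimethylamino)propyl on an oxygen on an aromatic ring.

Going by the values given here, two measured steps bear on this change, and both end on the dimethylamino chain of compound 3. They are an at least 1.8-fold lower number from compound 1 to compound 3 (0.25 log units; that floor lies within the scatter) and an at least 1.8-fold lower number from compound 2 to compound 3 (0.25 log units; that floor lies within the scatter) and each gives only a floor set by a limit. Neither compound 1 nor compound 2 has the dimethylamino group, and compound 4 loses it too, so compound 4 is expected to read more like those two. The expected change is a 2.2-fold higher number from compound 3 to compound 4 (0.33 log units; beyond the scatter) in the direction of a higher number, and it is modest. In this assay the estimate for compound 4 is 12000 nM within an expected range of 5000 nM to 30000 nM and the assay may well report only a limit.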

Compound 4, half-maximal inhibitory concentration: 100 nM
Estimate against measurement, compound 4: 120-fold (2.08 log units) above, and the stated range ends above it.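

In this assay, for the compounds shown here, this oxygen on an aromatic ring proves able to carry a large change, which the earlier compounds, with their small floors, gave no sign of: butylcarbonyl in place of 3-(dimethylamino)propyl gives a 56-fold lower number from compound 3 to compound 4 (1.74 log units; beyond the scatter), although the two groups have the same count of heavy atoms. The same group in place of allyl gives an at least 100-fold lower number from compound 2 to compound 4 (2.00 log units; beyond the scatter), and in place of 3-methylbut-2-en-1-yl it gives an at least 100-fold lower number from compound 1 to compound 4 (2.00 log units; beyond the scatter); these two steps are floors and not sizes because their starting compounds sit at a limit of the assay: the limit of > 10000 nM in this assay, at which 2 of the 4 values shown sit. With all three steps beyond the scatter, compound 4 is the strongest of the four and the only one with a carbonyl bound to this oxygen, while the three with a saturated chain carbon there all read far higher.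

Whether the low number belongs to the carbonyl or to the butyl chain behind it stays open, as butylcarbonyl is the only such group shown. From the compounds shown here alone, an acetyl group, a pentyl chain or a free hydroxyl on this oxygen would help separate the two, and how any of them reads is unknown.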